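The source may hold more compounds than are shown below. What is called first, only, known or untested is meant among the compounds shown, and "the series" means these compounds.

Series notes. Compound 1 `COc1cc(F)c(NC(=O)c2ccnc(O)c2)cc1Nc1nccc(-c2cn(C)c3ccccc23)n1` and compound 2 `COc1cc(N(C)CCN(C)C)c(NC(=O)c2ccnc(O)c2)cc1Nc1nccc(-c2cn(C)c3ccccc23)n1` share one core and differ at a single aromatic carbon. In a functional assay on NCI-H1975 cells (Homo sapiens) for antiproliferative activity, read by MTT assay, with a stated time of 72 h (on this read-out higher numbers stand for weaker inhibition and lower numbers for stronger inhibition), compound 1 gives 5920 nM. In this assay compound 2 gives 12000 nM, the highest of the two numbers recorded so far; the change between them is a 2.0-fold higher number from compound 1 to compound 2 (0.31 log units; beyond the scatter). Compound 3 `COc1cc(N(C)CCN(C)C)c(NC(=O)c2cnccn2)cc1Nc1nccc(-c2cn(C)c3ccccc23)n1` is the next member and has not yet been measured in this assay. Its difference from compound 2 is pyrazin-2-yl in place of 2-hydroxypyridin-4-yl on a carbonyl carbon. Within the data shown here, no measured step touches this part of the molecule: the only step available, a 2.0-fold higher number from compound 1 to compound 2 (0.31 log units; beyond the scatter), concerns a different substituent and says nothing about the ring attached to the carbonyl carbon. The expectation therefore rests only on this being a swap of one six-membered aromatic ring for another at the same attachment point, and there is no basis for predicting a step in either direction beyond the scatter, so the range is kept wide. Compound 3 is accordingly estimated at 12000 nM, within 4000 nM to 36000 nM. The expected step is no change at the digits printed from compound 2 to compound 3 (within the scatter).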

Compound 3, half-maximal inhibitory concentration: 1220 nM
Estimate against measurement, compound 3: 9.8-fold (0.99 log units) above; measured number below the stated range.
By their numbers in this assay, from the lowest: compound 3; then compound 1; then compound 2.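

In this assay, the group on the carbonyl carbon turns out to be a place where the read-out moves: pyrazin-2-yl in place of 2-hydroxypyridin-4-yl gives a 9.8-fold lower number from compound 2 to compound 3 (0.99 log units; beyond the scatter), a larger step than the only one available before, a 2.0-fold higher number from compound 1 to compound 2 (0.31 log units; beyond the scatter), which lay at a different aromatic carbon. The swap keeps a six-membered aromatic ring and the count of hydrogen-bond acceptors, but it loses the hydrogen-bond donor and goes from one ring hetero atom to two. Nothing at hand explains the step or assigns it to any one of these differences.

The compounds shown leave open whether pyrazin-2-yl gives a step of similar size when fluoro, rather than (2-(dimethylamino)ethyl)(methyl)amino, sits on the aromatic carbon. They also leave open how a plain phenyl or an unsubstituted pyridinyl ring on the carbonyl carbon would read, which would separate the loss of the hydroxy group from the gain of a second ring nitrogen.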